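The source may hold more compounds than are shown below. What is called first, only, known or untested is meant among the compounds shown, and "the series" means these compounds.

Compound 1 `O=C(OC1(C(=O)Nc2ccc([N+](=O)[O-])cc2)CCCCC1)c1ccc(C(F)(F)F)cc1` gives the lowest number of the three compounds measured in a functional assay on MCF7 cells (Homo sapiens) for inhibition, read by MTT assay, with a stated time of 72 h (on this read-out higher numbers stand for weaker inhibition and lower numbers for stronger inhibition), at 27.1 nM. Compound 3 `O=COC1(C(=O)Nc2ccc([N+](=O)[O-])cc2)CCCCC1` gives 35.4 nM, a step of a 1.3-fold higher number from compound 1 to compound 3 (0.12 log units; within the scatter), while compound 2 `O=C(OC1(C(=O)Nc2ccc([N+](=O)[O-])cc2)CCCCC1)c1ccccc1` gives 903 nM, a step of a 33-fold higher number from compound 1 to compound 2 (1.52 log units; beyond the scatter). Compound 4 `CC(=O)Oc1ccccc1C(=O)OC1(C(=O)Nc2ccc([N+](=O)[O-])cc2)CCCCC1` differs from compound 1 by 2-acetoxyphenyl in place of 4-(trifluoromethyl)phenyl on a carbonyl carbon. The measured steps that bear on this pull in opposite directions: dropping the whole aryl group, as in compound 3, costs little, whereas keeping an aryl ester without trifluoromethyl, as in compound 2, costs much, with a 26-fold lower number from compound 2 to compound 3 (1.41 log units; beyond the scatter) the recovery on going to the formate. Going by these compounds, compound 4 keeps an aryl ester lacking trifluoromethyl, so a weaker number than compound 1 is expected, though the 2-acetoxyphenyl group itself is untested. Compound 4 is estimated at 250 nM (range 50 nM to 1200 nM), a step of a 9.2-fold higher number from compound 1 to compound 4 (0.96 log units; beyond the scatter).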

Compound 4, half-maximal inhibitory concentration: 16.9 nM
The estimate for compound 4 lay 15-fold (1.17 log units) above the measured number; the measured number lies below the stated range.
By their numbers in this assay, from the lowest: compounds 4, 1 and 3 (each within the scatter of the next, the first and the last beyond it); then compound 2.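

In this assay, an aryl ester on this carbonyl carbon can do without trifluoromethyl: 2-acetoxyphenyl in place of 4-(trifluoromethyl)phenyl gives a 1.6-fold lower number from compound 1 to compound 4 (0.21 log units; within the scatter). Acetoxy in place of hydrogen on the aromatic carbon gives a 53-fold lower number from compound 2 to compound 4 (1.73 log units; beyond the scatter), while 2-acetoxyphenyl in place of hydrogen on the carbonyl carbon gives a 2.1-fold lower number from compound 3 to compound 4 (0.32 log units; beyond the scatter), a modest step. No evidence on the cause of these steps is at hand.

Going by these compounds, it remains open whether a hydroxyl, a methoxy or a carboxylic acid in place of acetoxy would give a similar number. On these data alone, the effect of moving acetoxy elsewhere on the aromatic ring also remains open.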